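The source may hold more compounds than are shown below. What is called first, only, known or untested is meant among the compounds shown, and "the series" means these compounds.

In a functional assay on MCF7 cells (Homo sapiens) for antiproliferative activity, read by MTT assay, with a stated time of 48 h (on this read-out lower numbers stand for stronger inhibition and higher numbers for weaker inhibition), three compounds sharing one core have been measured so far. Compound 1 `CC(=O)OC/C1=C/C[C@](C)(CCC=C(C)C)/C=C/[C@@H](OC(=O)C=C(C)C)[C@](C)(O)/C=C/C1=O` gives 4510 nM and compound 2 `COC/C1=C/C[C@](C)(CCC=C(C)C)/C=C/[C@@H](OC(=O)C=C(C)C)[C@](C)(O)/C=C/C1=O` gives 4130 nM, and a 1.1-fold lower number from compound 1 to compound 2 (0.04 log units; within the scatter) shows that acetoxy and methoxy cannot be told apart here. Compound 3 `CC(C)=CCC[C@]1(C)/C=C/[C@@H](OC(=O)C=C(C)C)[C@](C)(O)/C=C/C(=O)/C(CCl)=C\C1` gives 610 nM, the lowest of the three numbers. The steps leading to it, a 7.4-fold lower number from compound 1 to compound 3 (0.87 log units; beyond the scatter) and a 6.8-fold lower number from compound 2 to compound 3 (0.83 log units; beyond the scatter), are modest but beyond the scatter.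

Compound 4 `CCN(CC)C/C1=C/C[C@](C)(CCC=C(C)C)/C=C/[C@@H](OC(=O)C=C(C)C)[C@](C)(O)/C=C/C1=O` has diethylamino in place of chloro on a saturated chain carbon bound to a double-bonded ring carbon. Within the data shown here, no measured compound carries diethylamino, so no step speaks to this group directly. Among the measured compounds shown here, the only guidance comes from the steps that introduce chloro, which are the two above in reverse. Chloro is the only group of the three that stands apart, so removing it is expected to give back a step of similar, modest size, towards a higher number in this assay. That expectation is uncertain, since the entering group differs from both acetoxy and methoxy. The expected step is a 4.1-fold higher number from compound 3 to compound 4 (0.61 log units; beyond the scatter). For compound 4 the estimated value is 2500 nM, with an expected range of 700 nM to 9000 nM.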

Compound 4, half-maximal inhibitory concentration: 130 nM
Compound 4: middle estimate off by 19-fold (1.28 log units), on the high side; measured number below the stated range.
By their numbers in this assay, from the lowest: compound 4; then compound 3; then compounds 2 and 1 (each within the scatter of the next).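

In this assay, the saturated chain carbon bound to a double-bonded ring carbon proves able to carry more than chloro: diethylamino in its place gives a further modest fall in the number (a 4.7-fold lower number from compound 3 to compound 4 (0.67 log units; beyond the scatter)), and the lowest number of the series now belongs to an amine rather than a halogen. Measured against the oxygen-linked groups, the same change is large, with a 32-fold lower number from compound 2 to compound 4 (1.50 log units; beyond the scatter) and a 35-fold lower number from compound 1 to compound 4 (1.54 log units; beyond the scatter), so this one position spans a wider range in this read-out than the first three compounds revealed. Nothing available here accounts for this order of the groups.

Diethylamino is the only amine among the compounds shown, so it stays open whether the lower number goes with the nitrogen itself or with the ethyl chains, and dimethylamino, a plain primary amine, piperidine or morpholine at the same place would separate these readings. On these data alone, it also stays open how a carboxylic acid on this chain carbon would compare, and whether the order of the groups holds beyond this assay.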